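Replacing the nitrophenyl amide with a fluorophenyl amide

The source may report more compounds than this note shows. Statements on the series, on what has been measured and on what is new or still open speak of the compounds shown alone.

Three compounds share one core and differ only in the aryl group attached to the amide nitrogen. Compound 1 `O=C(CSc1nc(Nc2ccccc2)c2ccccc2n1)Nc1ccccc1Br` carries a 2-bromophenyl there; in a functional assay on NCI-H1975 cells (Homo sapiens) for inhibition, read by MTT assay, with a stated time of 72 h (on this read-out higher numbers stand for weaker inhibition and lower numbers for stronger inhibition), compound 1 gives 10300 nM. Compound 2 `O=C(CSc1nc(Nc2ccccc2)c2ccccc2n1)Nc1cccc(Br)c1` carries a 3-bromophenyl, and in this assay compound 2 gives 10100 nM. Compound 3 `O=C(CSc1nc(Nc2ccccc2)c2ccccc2n1)Nc1cccc([N+](=O)[O-])c1` carries a 3-nitrophenyl, and in this assay compound 3 gives 17900 nM, the highest of the three numbers, although its distances to the other two are small: a 1.7-fold higher number from compound 1 to compound 3 (0.24 log units; within the scatter) and a 1.8-fold higher number from compound 2 to compound 3 (0.25 log units; within the scatter). The move between the two bromo compounds is smaller still: a 1.0-fold lower number from compound 1 to compound 2 (0.01 log units; within the scatter).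

Compound 4 `O=C(CSc1nc(Nc2ccccc2)c2ccccc2n1)Nc1ccc(F)cc1` is the next step and differs from compound 3 in one place: 4-fluorophenyl in place of 3-nitrophenyl on an amide-type nitrogen. Every step measured so far alters this same aryl group on the amide nitrogen, and none of them moved this assay beyond the scatter, whether bromo was exchanged for nitro or shifted around the ring. Within the data shown here, no measured step exchanges a nitro for a fluoro or introduces a 4-fluorophenyl, so the guidance is indirect. On this basis the step to compound 4 is expected to be a 1.5-fold lower number from compound 3 to compound 4 (0.17 log units; within the scatter), no change beyond the scatter. In this assay compound 4 is therefore expected to give 12000 nM, within a range from 5000 nM to 30000 nM.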

Compound 4, half-maximal inhibitory concentration: 16500 nM
Estimate against measurement, compound 4: 1.4-fold (0.14 log units) below; low and high end bracket the measured number.
By their numbers in this assay, from the lowest: compounds 2, 1, 4 and 3 (each within the scatter of the next).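

Putting a 4-fluorophenyl in place of the 3-nitrophenyl on the amide-type nitrogen gives a 1.1-fold lower number from compound 3 to compound 4 (0.04 log units; within the scatter) in this assay, so a group of 7 heavy atoms with no hydrogen-bond acceptors reads the same here as one of 9 heavy atoms with 2 acceptors. The comparisons with the two bromo compounds agree, with a 1.6-fold higher number from compound 2 to compound 4 (0.21 log units; within the scatter) and a 1.6-fold higher number from compound 1 to compound 4 (0.20 log units; within the scatter), which means that all four aryl groups now sit within the scatter of one another and none of the changes at this position has yet shifted the number in a way that can be trusted. Nothing measured on these compounds explains why the numbers stay so close.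

On these data alone, what remains open is whether any group on this nitrogen can move the number beyond the scatter at all, for example a phenyl carrying an amine or a carboxylic acid, or a longer chain in place of the aryl ring. The compounds shown also leave open how the number responds to changes elsewhere, since the shared core and its phenylamino group stay the same in all four.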